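A few compounds are considered here, and "the series" means these few. Any claim that something is new, unique, unknown or untested is made for them only; others in the source may bear on it.

In a functional assay on NCI-H460 cells (Homo sapiens) for inhibition, read by sulforhodamine B assay, with a stated time of 48 h (on this read-out higher numbers stand for weaker inhibition of growth and lower numbers for stronger inhibition of growth), three compounds have been measured. Compound 1 `N#CCC1=C(C#N)CC(c2ccc([N+](=O)[O-])cc2)=C(CC(=O)c2ccc([N+](=O)[O-])cc2)O1` gives 80 nM, compound 2 `N#CCC1=NN=C(c2ccc([N+](=O)[O-])cc2)CO1` gives 2 nM and compound 3 `N#CCC1=NN=C(c2ccc([N+](=O)[O-])cc2)C(Br)O1` gives 8500 nM, so compound 2 has the lowest number, beyond the scatter from both others. Compound 4 `N#CCC1=NN=C(c2ccc(Br)cc2)CO1` carries bromo in place of nitro on an aromatic carbon of compound 2 (bromo in place of nitro on an aromatic carbon). Among the compounds with values here, the only measured step that bears on this is large, a 4300-fold higher number from compound 2 to compound 3 (3.63 log units; beyond the scatter), and it also brings in bromo, but not on an aromatic carbon, so it is only a loose guide. Within the data shown here, no measured step replaces nitro. A higher number in this assay is expected, well short of that step, at an estimated 10-fold higher number from compound 2 to compound 4 (1.00 log units; beyond the scatter). For compound 4 the expected value is 20 nM, with an estimated range from 2 nM to 300 nM.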

Compound 4, concentration for 50% growth inhibition: 900 nM
Estimate against measurement, compound 4: 45-fold (1.65 log units) below, and the stated range ends below it.
By their numbers in this assay, from the lowest: compound 2; then compound 1; then compound 4; then compound 3.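

In this assay, replacing the nitro on the aromatic carbon with bromo gives a 450-fold higher number from compound 2 to compound 4 (2.65 log units; beyond the scatter). Within the data shown here, the earlier compounds left this position unchanged, so this is the first sign that the group there matters greatly, and the core of compound 2 alone does not secure a low number. Nothing measured here gives a reason for the size of this step. Going by these compounds, it remains open whether an amine or a carboxylic acid at this position would give a number closer to that of compound 2 or to that of compound 4.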